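This account rests on a few compounds, and the source may have more. Where it says the series, first, only, none or still open, it means among the compounds named here.

Values in a functional assay on HepG2 cells (Homo sapiens) for antiproliferative activity, read by MTT assay, with a stated time of 48 h; a higher number here means a weaker inhibitor, a lower number a stronger inhibitor:
- compound 1 `COc1ccc(N(C)c2ccnc(Cl)n2)cc1`: 2120 nM
- compound 2 `COc1ccc(N(C)c2ccnc(Cl)n2)cc1F`: 844 nM
- compound 3 `COc1ccc(N(C)c2ccnc(Cl)n2)cc1[N+](=O)[O-]`: 6120 nM

Compound 3 has the highest number of the three. Compound 4 `COc1ccc(N(C)c2ccnc(Cl)n2)cc1OCCBr` carries 2-bromoethoxy in place of nitro on an aromatic carbon, ortho to a methoxy group: 2-bromoethoxy in place of nitro on an aromatic carbon.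

The measured steps at this carbon are a 2.9-fold higher number from compound 1 to compound 3 (0.46 log units; beyond the scatter) and a 7.3-fold higher number from compound 2 to compound 3 (0.86 log units; beyond the scatter), both upward on entering nitro, and a 2.5-fold lower number from compound 1 to compound 2 (0.40 log units; beyond the scatter) on entering fluoro. Within the data shown here, no measured compound has an ether chain at this carbon, so the size of the step remains uncertain. Loss of nitro is expected to bring a modest fall in this assay, comparable to a 2.9-fold higher number from compound 1 to compound 3 (0.46 log units; beyond the scatter) in reverse.

The expected change is a 2.8-fold lower number from compound 3 to compound 4 (0.44 log units; beyond the scatter). For compound 4 the estimated value is 2200 nM, with an expected range of 600 nM to 7500 nM.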

Compound 4, half-maximal inhibitory concentration: 7720 nM
Estimate against measurement, compound 4: 3.5-fold (0.55 log units) below, and the stated range ends below it.
By their numbers in this assay, from the lowest: compound 2; then compound 1; then compounds 3 and 4 (each within the scatter of the next).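

In this assay, replacing nitro by 2-bromoethoxy on this aromatic carbon, ortho to a methoxy group, gives a 1.3-fold higher number from compound 3 to compound 4 (0.10 log units; within the scatter) and leaves the two groups indistinguishable. Set against hydrogen and fluoro at the same carbon, 2-bromoethoxy gives a 3.6-fold higher number from compound 1 to compound 4 (0.56 log units; beyond the scatter) and a 9.1-fold higher number from compound 2 to compound 4 (0.96 log units; beyond the scatter), so the higher number is not confined to nitro. No measurement at hand bears on the reason. As far as these compounds go, whether the bromine matters remains open, as a plain ethoxy, a longer chain or an amine at this carbon would be needed to separate it from the ether chain. From the compounds shown here alone, whether any group here betters fluoro also remains open.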